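From sulfonyl to benzoyl on the shared core

The source may hold more compounds than are shown below. What is called first, only, known or untested is meant among the compounds shown, and "the series" means these compounds.

Three compounds built on a shared core have numbers in a functional assay on MCF7 cells (Homo sapiens) for cytotoxicity, read by sulforhodamine B assay, with a stated time of 24 h; a lower number here means a stronger inhibitor, a higher number a weaker inhibitor. Compound 1 (`N=c1oc2ccccc2cc1C(=O)N/N=C1\C(=O)Nc2ccc(S(=O)(=O)N3CCOCC3)cc21`) gives 20800 nM, compound 2 (`O=C1Nc2ccc(S(=O)(=O)N3CCOCC3)cc2/C1=N/c1ccc(Br)cc1`) gives 44800 nM, and compound 3 (`Cc1ccc(S(=O)(=O)N/N=C2\C(=O)Nc3ccc(S(=O)(=O)N4CCOCC4)cc32)cc1`) gives 38400 nM. Compound 3 stands within the scatter of both other compounds, so it offers no clear separation from either. Within the data shown here, no measured pair differs in only one place, so the series gives no direct guide to a single change.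

Compound 4 (`O=C1Nc2ccc(S(=O)(=O)N3CCOCC3)cc2/C1=N/NC(=O)c1ccccc1`) has benzoyl in place of (4-methylphenyl)sulfonyl on an amine nitrogen. Among the measured compounds shown here, the closest available comparison is compound 1, which also has a carbonyl on that amine nitrogen and gives 20800 nM, a value within the scatter of the one for compound 3. In this assay, the expected change is a 1.3-fold lower number from compound 3 to compound 4 (0.11 log units; within the scatter), a small drop to a lower number that stays within the scatter. For compound 4, the estimated value is 30000 nM, with an expected range of 14000 nM to 62000 nM.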

Compound 4, half-maximal inhibitory concentration: 414000 nM
Estimate against measurement, compound 4: 14-fold (1.14 log units) below; measured number above the stated range.
By their numbers in this assay, from the lowest: compounds 1, 3 and 2 (each within the scatter of the next, the first and the last beyond it); then compound 4.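

In this assay, benzoyl does not stand in for (4-methylphenyl)sulfonyl on this amine nitrogen, whose other neighbour is a double-bonded nitrogen (an 11-fold higher number from compound 3 to compound 4 (1.03 log units; beyond the scatter)). A carbonyl on that nitrogen is therefore not enough on its own, and the group on the carbonyl carbon matters: exchanging the larger group of compound 1 for the six-carbon aromatic ring gives a sharp rise (a 20-fold higher number from compound 1 to compound 4 (1.30 log units; beyond the scatter)), while benzamido in place of 4-bromophenyl on a double-bonded nitrogen also gives a higher number (a 9.2-fold higher number from compound 2 to compound 4 (0.97 log units; beyond the scatter)). No evidence here gives a cause for these steps.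

As far as these compounds go, it remains open whether 4-methylbenzoyl or acetyl on the same amine nitrogen would stay with compound 4 or fall with compound 1 and compound 3. Methanesulfonyl at that nitrogen would test whether the sulfonyl link alone goes with the lower numbers.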